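Chloro to Bromo: a Single Halogen Swap

This account rests on a few compounds, and the source may have more. Where it says the series, first, only, none or still open, it means among the compounds named here.

Measured compounds:
compound 1 `COc1ccc(S(=O)(=O)NCCN2CCC(CCC(=O)c3cc(Cl)c(N)cc3OC)CC2)cc1Cl` — 22.5 nM in an assay on brain for displacement of a labelled ligand from 5-hydroxytryptamine receptor 4 (Cavia porcellus), with a stated time of 30 min, in the presence of a further agent that is not named here; a higher number here means a weaker inhibitor, a lower number a stronger inhibitor
compound 2 `COc1ccc(S(=O)(=O)N2CCC(CCC(=O)c3cc(Cl)c(N)cc3OC)CC2)cc1` — "not determined" (no result reported) in this assay

Among the measured compounds shown here, compound 1 is the only compound here with a number in this assay, where compound 1 gives 22.5 nM. Compound 2 carries no result, so nothing can be said about how it compares. Compound 3 `COc1ccc(S(=O)(=O)NCCN2CCC(CCC(=O)c3cc(Cl)c(N)cc3OC)CC2)cc1Br` has not yet been measured. Compound 3 differs from compound 1 in one place: bromo in place of chloro on an aromatic carbon. For the measured compounds named here, no measured pair shows what such a swap does. A change of one halogen for the next on an aromatic carbon is expected to move the inhibition constant little, with no direction favoured beyond the usual scatter. The step from compound 1 to compound 3 is therefore estimated at a 1.0-fold lower number from compound 1 to compound 3 (0.01 log units; within the scatter). Compound 3 is expected to give about 22 nM, within a range from 8 nM to 60 nM.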

Compound 3, inhibition constant: 24.3 nM
Estimate against measurement, compound 3: 1.1-fold (0.04 log units) below; low and high end bracket the measured number.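

In this assay, replacing chloro with bromo gives a 1.1-fold higher number from compound 1 to compound 3 (0.03 log units; within the scatter), so this pair cannot be told apart. Among the compounds shown here, this is the first measured pair to read this position directly: on this aromatic carbon, ortho to a methoxy group, bromo serves as well as chloro, and the 3-bromo-4-methoxyphenyl group keeps the binding seen with 3-chloro-4-methoxyphenyl. Nothing available explains why the two halogens read alike.

From the compounds shown here alone, with only these two halogens compared, the effect of fluoro, methyl or an amine on the same carbon remains open, so the limits of what this position accepts are still unknown. It is also unknown whether the same swap would read alike in this assay if the methoxy group gave way to a longer chain such as ethoxy.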